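From Dimethylamide Back to an Aryl Ether

The source may hold more compounds than are shown below. What is called first, only, known or untested is meant among the compounds shown, and "the series" means these compounds.

Compound 1 `CC(C)C[C@H](N)c1cc(C(F)(F)F)ccc1N1CCN(C(=O)C(C)Cc2ccc(Cl)cc2O)CC1` is the reference point of the pair measured so far: in an assay on HEK293 cells for displacement of a labelled ligand from Melanocortin receptor 4 (Homo sapiens) (on this read-out higher numbers stand for weaker inhibition and lower numbers for stronger inhibition), compound 1 gives 36 nM. Compound 2 `CC(C)C[C@H](N)c1cc(C(F)(F)F)ccc1N1CCN(C(=O)CCC(=O)N(C)C)CC1` carries a 2-(dimethylcarbamoyl)ethyl in place of the 1-(4-chloro-2-hydroxybenzyl)ethyl on the carbonyl carbon. In this assay compound 2 gives only a limit, > 10000 nM, so its binding is not resolved as a number. The step of an at least 270-fold higher number from compound 1 to compound 2 (2.44 log units; beyond the scatter) is thus a lower bound on the loss, because one of the two values sits at the limit of > 10000 nM in this assay, at which 1 of the 2 values shown sits. Compound 3 `Cc1ccc(OCC(=O)N2CCN(c3ccc(C(F)(F)F)cc3[C@@H](N)CC(C)C)CC2)c(C)c1` is still to be measured; it differs from compound 2 as 2,4-dimethylphenoxy in place of (dimethylcarbamoyl)methyl on a saturated chain carbon bound to a carbonyl carbon. Among the measured compounds shown here, this change puts an aromatic ring back where compound 2 has none, so the single measured step, an at least 270-fold higher number from compound 1 to compound 2 (2.44 log units; beyond the scatter), read in reverse, argues for a move to a lower number. The estimate for compound 3 is 300 nM, with a range from 40 nM to 3000 nM. The expected step of an at least 33-fold lower number from compound 2 to compound 3 (1.52 log units; beyond the scatter) is a return toward stronger binding, though the aromatic group of compound 3 is not that of compound 1, so full recovery is uncertain.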

Compound 3, inhibition constant: 4000 nM
For compound 3 the middle estimate is 13-fold (1.12 log units) below the measured one; measured number above the stated range.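

In this assay, 2,4-dimethylphenoxy in place of (dimethylcarbamoyl)methyl on a saturated chain carbon bound to a carbonyl carbon gives binding that can be read as a number (an at least 2.5-fold lower number from compound 2 to compound 3 (0.39 log units; beyond the scatter)). That step is only a lower bound because compound 2 is held as a limit: the limit of > 10000 nM in this assay, at which 1 of the 3 values shown sits. An aromatic ring at this place is therefore not enough on its own, as (2,4-dimethylphenoxy)methyl in place of 1-(4-chloro-2-hydroxybenzyl)ethyl on a carbonyl carbon still costs much of the binding (a 110-fold higher number from compound 1 to compound 3 (2.05 log units; beyond the scatter)).

The compounds shown leave open whether the ether oxygen or the two methyl groups of the ring account for that loss. They also leave open how a chlorophenoxy or a hydroxyphenoxy group would read at this place.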